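Swapping the aryl group on a sulfonamide: compound 3 to compound 4

The compounds below may be only part of what the source reports. "The series", "measured", "known", "first", "only" and "open" are said of these compounds alone.

Three sulfonamides share one core and differ only in the aryl group on the sulfonamide nitrogen. In a functional assay on MCF7 cells (Homo sapiens) for antiproliferative activity, read by sulforhodamine B assay, with a stated time of 48 h (a higher number here means a weaker inhibitor, a lower number a stronger inhibitor), compound 1 `CCCCc1ccc(NS(=O)(=O)c2ccc(N3CCNC3=O)cc2)cc1` gives 770 nM, compound 2 `O=C1NCCN1c1ccc(S(=O)(=O)Nc2ccccc2)cc1` gives 470 nM and compound 3 `CCc1cccc(NS(=O)(=O)c2ccc(N3CCNC3=O)cc2)c1` gives 130 nM. Removing the butyl is a small step, a 1.6-fold lower number from compound 1 to compound 2 (0.21 log units; within the scatter), while adding an ethyl is a modest one, a 3.6-fold lower number from compound 2 to compound 3 (0.56 log units; beyond the scatter). Compound 3 therefore holds the lowest number of the three, separated from compound 2 and from compound 1 by steps beyond the scatter.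

Compound 4 `COc1ccc(NS(=O)(=O)c2ccc(N3CCNC3=O)cc2)cc1` is not yet measured. It arises from compound 3 by the change (4-methoxyphenyl in place of 3-ethylphenyl on a sulfonamide nitrogen). Going by the values given here, no measured step replaces one aryl substituent by another of a different kind, so only the two steps above bear on it: the ethyl gave a modest gain, and the butyl gave a change within the scatter. As the ethyl that set compound 3 apart leaves, the number is expected to rise back toward the range of compound 2 and compound 1, a step of roughly a 3.8-fold higher number from compound 3 to compound 4 (0.59 log units; beyond the scatter) in this assay. For compound 4 an estimate of 500 nM is made, with a range from 150 nM to 1600 nM.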

Compound 4, half-maximal inhibitory concentration: > 1000 nM
Compound 4: a limit, no number; the forecaster's own chance of this, stated with the estimate: 3%; middle value at least 2.0-fold (0.30 log units) away from the limit.
By their numbers in this assay, from the lowest: compound 3; then compounds 2 and 1 (each within the scatter of the next). At a limit, above all of these: compound 4.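

In this assay, compound 4 carries a limit of the assay and not a number: the limit of > 1000 nM in this assay, at which 1 of the 4 values shown sits. Even as a floor, the result shows that this position tolerates the change poorly, with 4-methoxyphenyl in place of 3-ethylphenyl on the sulfonamide nitrogen giving an at least 7.6-fold higher number from compound 3 to compound 4 (0.88 log units; beyond the scatter), and it shows for the first time a substituent that moves the number up beyond the scatter from the unsubstituted phenyl compound, with methoxy in place of hydrogen giving an at least 2.1-fold higher number from compound 2 to compound 4 (0.32 log units; beyond the scatter). Against the butyl compound the floor is less informative, since methoxy in place of butyl gives an at least 1.2-fold higher number from compound 1 to compound 4 (0.11 log units; that floor lies within the scatter), so this comparison sets only a lower bound on the step.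

The compounds shown leave open whether the step follows the change of group or the change of its place on the ring, since 3-ethylphenyl and 4-methoxyphenyl differ in both. They also leave open how a 3-methoxyphenyl, a 4-ethylphenyl, or an aryl group carrying an amine or a carboxylic acid would read on the same core.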